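Benzylsulfonyl for methylsulfonyl: cytotoxicity notes on the series

The source may hold more compounds than are shown below. What is called first, only, known or untested is meant among the compounds shown, and "the series" means these compounds.

Measured so far, in an ADME assay on HEK293 cells (Homo sapiens) for cytotoxicity, read by MTT assay, with a stated time of 48 h; a lower number here means a stronger inhibitor, a higher number a weaker inhibitor:
compound 1, `CN(c1ccc(NC(=O)c2cc(C(F)(F)F)cc(C(F)(F)F)c2)cc1OCc1cccc(C(F)(F)F)c1)S(C)(=O)=O`, a limit, > 500000 nM
compound 2, `CN(c1ccc(NC(=O)c2ccc(C(F)(F)F)cc2C(F)(F)F)cc1OCc1cccc(C(F)(F)F)c1)S(C)(=O)=O`, a limit, > 500000 nM
compound 3, `CN(c1ccc(NC(=O)c2cc(C(F)(F)F)cc(C(F)(F)F)c2)cc1OCc1cccc(C(F)(F)F)c1)S(=O)(=O)Cc1ccccc1`, 59800 nM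

Compound 1 and compound 2 share their atoms but join them differently; the difference between the two cores is not broken down here. Compound 3 carries the change phenyl in place of hydrogen on a saturated chain carbon bound to a sulfonyl sulfur on the core of compound 1, and this gave an at least 8.3-fold lower number from compound 1 to compound 3 (0.92 log units; beyond the scatter). The size of that step rests on the limit of > 500000 nM in this assay, at which 2 of the 3 values shown sit, for compound 1, so only its lower bound is known.

Compound 4, `CN(c1ccc(NC(=O)c2ccc(C(F)(F)F)cc2C(F)(F)F)cc1OCc1cccc(C(F)(F)F)c1)S(=O)(=O)Cc1ccccc1`, is not yet measured. It carries the same change on the core of compound 2: phenyl in place of hydrogen on a saturated chain carbon bound to a sulfonyl sulfur. Both place lines read the same, so this is the same kind of change at the same kind of position. On the core of compound 2, the step is expected to be an at least 7.1-fold lower number from compound 2 to compound 4 (0.85 log units; beyond the scatter), by analogy with the measured step from compound 1 to compound 3, because compound 2 sits at the same limit as compound 1, (the limit of > 500000 nM in this assay, at which 2 of the 3 values shown sit). Compound 4 is therefore expected to give about 70000 nM in this assay , within 20000 nM to 300000 nM.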

Compound 4, half-maximal inhibitory concentration: 176000 nM
For compound 4 the middle estimate is 2.5-fold (0.40 log units) below the measured one, within the range that was stated.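

In this assay, benzylsulfonyl in place of methylsulfonyl also lowers the number on the core of compound 2, with an at least 2.8-fold lower number from compound 2 to compound 4 (0.45 log units; beyond the scatter). The direction of the step is therefore the same on both cores shown, but this does not establish that the change carries over with the same size: the same change on two cores in this assay, an at least 8.3-fold lower number (0.92 log units; beyond the scatter) from compound 1 to compound 3 and an at least 2.8-fold lower number (0.45 log units; beyond the scatter) from compound 2 to compound 4; the limit leaves it open whether they differ. Compound 2 gives > 500000 nM, which is a limit and not a number, so its step has only a lower bound, and the same limit applies to the other starting compound: the limit of > 500000 nM in this assay, at which 2 of the 4 values shown sit.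

On these data alone, it remains open how large the step would be on a core whose methylsulfonyl compound gives a value that can be read as a number, and whether it would hold on cores other than these two. Also open, as far as these compounds go, is whether a longer chain on the sulfonyl sulfur, or an amine or a carboxylic acid on the phenyl of the benzyl group, would give a step of similar size.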